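Hydroxy on the Fused Ring: Series Notes on HeLa Growth

A few compounds are considered here, and "the series" means these few. Any claim that something is new, unique, unknown or untested is made for them only; others in the source may bear on it.

Measured compounds:
compound 1 `Cc1c(-c2ccc(O)cc2)n(CCCCOc2ccccc2)c2ccccc12` — 11000 nM
compound 2 `Cc1c(-c2ccc(O)cc2)n(CCCCOc2ccccc2)c2ccc(O)cc12` — 4000 nM
compound 3 `Cc1c(-c2ccc(O)cc2)[nH]c2ccccc12` — > 20000 nM

The read-out throughout is a functional assay on HeLa cells (Homo sapiens) for inhibition, read by trypan blue exclusion, with a stated time of 72 h; on this read-out lower numbers stand for stronger inhibition of growth and higher numbers for weaker inhibition of growth. In this assay compound 1 gives 11000 nM. Compound 2 carries the change hydroxy in place of hydrogen on an aromatic carbon relative to compound 1, and in this assay compound 2 gives 4000 nM. The step is a 2.8-fold lower number from compound 1 to compound 2 (0.44 log units; beyond the scatter).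

Compound 3 stands apart from compound 1 in more than one place; how the two cores differ is not broken down here. For compound 3 this assay reports only a limit, > 20000 nM; this is a limit of the assay, not a number, see (the limit of > 20000 nM in this assay, at which 1 of the 3 values shown sits).

Compound 4 `Cc1c(-c2ccc(O)cc2)[nH]c2ccc(O)cc12` is not yet measured. It relates to compound 3 by hydroxy in place of hydrogen on an aromatic carbon, the same kind of change that separates compound 2 from compound 1, and the surroundings of the place are described in the same words in both cases.

For compound 4 a step of about an at least 1.3-fold lower number from compound 3 to compound 4 (0.12 log units; that floor lies within the scatter) is expected, resting on the step of a 2.8-fold lower number from compound 1 to compound 2 (0.44 log units; beyond the scatter) seen in this assay with the same change. Because compound 3 sits only at a limit (the limit of > 20000 nM in this assay, at which 1 of the 3 values shown sits), the starting point is uncertain, so the expected number for compound 4 remains close to that limit and may itself come back as a limit. The estimate for compound 4 in this assay is 15000 nM, with a likely range from 5000 nM to 50000 nM.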

Compound 4, concentration for 50% growth inhibition: 16000 nM
For compound 4 the middle estimate is 1.1-fold (0.03 log units) below the measured one, and the stated range covers the measured number.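

In this assay, hydroxy in place of hydrogen on an aromatic carbon of the core of compound 3 gives an at least 1.2-fold lower number from compound 3 to compound 4 (0.09 log units; that floor lies within the scatter), and set beside the earlier step the two read as follows: the same change on two cores in this assay, a 2.8-fold lower number (0.44 log units; beyond the scatter) from compound 1 to compound 2 and an at least 1.2-fold lower number (0.09 log units; that floor lies within the scatter) from compound 3 to compound 4; the limit leaves it open whether they differ. For compound 3 the value is a limit of the assay and not a number, so the new step is only a floor: the limit of > 20000 nM in this assay, at which 1 of the 4 values shown sits. The two cores therefore do not contradict carrying this change from one to the other, but they do not show that the step keeps its size, nor that it lies beyond the scatter on the core of compound 3.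

As far as these compounds go, the true size of the step on the core of compound 3 stays open, since it would take a number rather than a limit for compound 3, and two cores are too few to say how general the step is. Among the compounds shown here, also open is whether a methoxy or an amine in place of the hydroxy would give a step of the same kind, and whether the change would carry over to a core with a longer chain than the one in compound 1.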